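Swapping the indole group of compound 1

The source may report more compounds than this note shows. Statements on the series, on what has been measured and on what is new or still open speak of the compounds shown alone.

compound 1 `Cn1c(=O)c(S(=O)(=O)c2ccc(Cl)cc2)cc2cnc(Nc3ccc4[nH]ccc4c3)nc21` gives 100 nM
compound 2 `Cn1c(=O)c(S(=O)(=O)c2ccc(F)cc2[N+](=O)[O-])cc2cnc(Nc3ccc4[nH]ccc4c3)nc21` gives 900 nM

Both values come from a functional assay on K562 cells (Homo sapiens) for inhibition, read by trypan blue exclusion, with a stated time of 72 h (a higher number here means a weaker inhibitor, a lower number a stronger inhibitor), and compound 1 holds the lower number of the two, beyond the scatter. Compound 3 `Cn1c(=O)c(S(=O)(=O)c2ccc(Cl)cc2)cc2cnc(Nc3cnc4[nH]ccc4c3)nc21` differs from compound 1 on a nitrogen on an aromatic ring, and the change is a group of 9 heavy atoms (7 carbon, 2 nitrogen; one five-membered aromatic ring with 1 hetero atom, one six-membered aromatic ring with 1 hetero atom) in place of a group of 9 heavy atoms (8 carbon, 1 nitrogen; one five-membered aromatic ring with 1 hetero atom, one six-membered aromatic ring of carbon only), on a nitrogen on an aromatic ring with nothing else altered. Going by the values given here, the one measured step is a 9.0-fold higher number from compound 1 to compound 2 (0.95 log units; beyond the scatter) and it lies on a sulfonyl sulfur, so it bears only indirectly and shows what one swap can do. Among the compounds with values here, no measured step touches this group, so a smaller rise in the number is expected. The expected step is a 2.5-fold higher number from compound 1 to compound 3 (0.40 log units; beyond the scatter) in this estimate. Compound 3 is estimated at 250 nM with 70 nM to 800 nM as its range.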

Compound 3, half-maximal inhibitory concentration: 5000 nM
Estimate against measurement, compound 3: 20-fold (1.30 log units) below, outside the stated range (above it).
By their numbers in this assay, from the lowest: compound 1; then compound 2; then compound 3.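

In this assay, the group on a nitrogen on an aromatic ring proves highly sensitive to a small edit. Replacing 1H-indol-5-yl with a group of equal heavy-atom count, with one ring carbon exchanged for nitrogen and one hydrogen-bond acceptor gained, gives a 50-fold higher number from compound 1 to compound 3 (1.70 log units; beyond the scatter). Nothing available accounts for this loss.

On these data alone, it remains open how a methoxy group or an amine on the six-membered ring of 1H-indol-5-yl would fare. Also open, as far as these compounds go, is whether the same change costs as much with 4-fluoro-2-nitrophenyl on the sulfonyl sulfur.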